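Notes on the step from methyl to fluoro

The source may hold more compounds than are shown below. What is called first, only, known or untested is meant among the compounds shown, and "the series" means these compounds.

Compound 1 `c1ccc(-c2nnc(COc3ccc(-c4nnco4)cc3)o2)cc1`: > 50000 nM, a limit.
Compound 2 `COc1ccc(-c2nnc(COc3ccc(-c4nnco4)cc3)o2)cc1`: 36200 nM.
Compound 3 `Cc1ccc(-c2nnc(COc3ccc(-c4nnco4)cc3)o2)cc1`: > 50000 nM, a limit.

All values come from a functional assay on MDA-MB-453 cells (Homo sapiens) for cytotoxicity, read by MTT assay, with a stated time of 48 h; on this read-out lower numbers stand for stronger inhibition and higher numbers for weaker inhibition. Compound 3 is known in this assay only as a limit, > 50000 nM. Compound 4 `Fc1ccc(-c2nnc(COc3ccc(-c4nnco4)cc3)o2)cc1` differs from it by fluoro in place of methyl on an aromatic carbon. Two measured steps at this place bear on the change: a step that the two limits leave unreadable from compound 1 to compound 3 and an at least 1.3-fold higher number from compound 2 to compound 3 (0.14 log units; that floor lies within the scatter). Among the measured compounds shown here, the series so far shows (the limit of > 50000 nM in this assay, at which 2 of the 3 values shown sit), and compound 2 goes against that pattern. No step beyond the scatter is therefore expected, and a further limit is likely. The expected change is a number no higher from compound 3 to compound 4 (the limit leaves the size open). Compound 4 is estimated at 50000 nM, with an expected range of 30000 nM to 90000 nM.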

Compound 4, half-maximal inhibitory concentration: 38200 nM
Compound 4: middle estimate off by 1.3-fold (0.12 log units), on the high side, and the stated range covers the measured number.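

In this assay, 4-fluorophenyl gives a measured number at this place on the ring, whereas 4-methylphenyl gave only a limit: an at least 1.3-fold lower number from compound 3 to compound 4 (0.11 log units; that floor lies within the scatter), and an at least 1.3-fold lower number from compound 1 to compound 4 (0.11 log units; that floor lies within the scatter). Fluoro in place of methoxy gives a 1.1-fold higher number from compound 2 to compound 4 (0.02 log units; within the scatter), so the two substituents that give measured numbers here cannot be told apart. The limit still marks the rest of the series: the limit of > 50000 nM in this assay, at which 2 of the 4 values shown sit.

The full size of the steps out of compound 1 and compound 3 remains unread. As far as these compounds go, whether an amine or a carboxylic acid at this place would give a step beyond the scatter stays open.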